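Acrylic acid series: shifting methoxy groups on the aryl ring

The source may hold more compounds than are shown below. What is called first, only, known or untested is meant among the compounds shown, and "the series" means these compounds.

Measured so far:
Compound 1, `CC(=O)n1cc(/C=C(/C(=O)O)c2ccccc2)c2cc(OCc3ccccc3)ccc21`, gives 57500 nM in a functional assay on A549 cells (Homo sapiens) for cytotoxicity, read by MTT assay, with a stated time of 72 h; a higher number here means a weaker inhibitor, a lower number a stronger inhibitor.
Compound 2, `COc1ccc(OC)c(/C(=C\c2cn(C(C)=O)c3ccc(OCc4ccccc4)cc23)C(=O)O)c1`, gives 54500 nM in this assay.

Compound 2 and compound 1 lie within the scatter of each other; the two numbers do not separate them. For the measured compounds named here, the only measured step, a 1.1-fold lower number from compound 1 to compound 2 (0.02 log units; within the scatter), changed the aryl group on the acrylic acid carbon without effect beyond the scatter. Compound 3, `COc1ccc(/C(=C\c2cn(C(C)=O)c3ccc(OCc4ccccc4)cc23)C(=O)O)cc1OC`, differs from compound 2 in that (3,4-dimethoxyphenyl in place of 2,5-dimethoxyphenyl on a double-bonded chain carbon bound to a carbonyl carbon and a double-bonded chain carbon). Going by the values given here, with the one relevant step flat, no change beyond the scatter is expected in this assay; the estimated step is a 1.1-fold lower number from compound 2 to compound 3 (0.04 log units; within the scatter). Compound 3 is expected at 50000 nM, between 20000 nM and 130000 nM.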

Compound 3, half-maximal inhibitory concentration: 54800 nM
Compound 3: middle estimate off by 1.1-fold (0.04 log units), on the low side, and the stated range covers the measured number.
By their numbers in this assay, from the lowest: compounds 2, 3 and 1 (each within the scatter of the next).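

In this assay, the swap of 2,5-dimethoxyphenyl for 3,4-dimethoxyphenyl gives a 1.0-fold higher number from compound 2 to compound 3 (0.00 log units; within the scatter), so at this place the two methoxy arrangements are not separated. The second dimethoxy pattern also stays level with plain phenyl, at a 1.0-fold lower number from compound 1 to compound 3 (0.02 log units; within the scatter), and the flat result now holds for both patterns. No supporting data explain this flatness.

Open, from the compounds shown here alone, is whether any group on this aryl ring moves the number beyond the scatter, for example an amine, a nitrile or a longer chain in place of methoxy.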